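A Tetrazole in Place of a Nitrile

A few compounds are considered here, and "the series" means these few. Any claim that something is new, unique, unknown or untested is made for them only; others in the source may bear on it.

compound 1 `CC(=O)c1cc(C)c(OCCCCC#N)cc1O`: 35%
compound 2 `CCc1cc(C(C)=O)c(O)cc1OCCCCC(C)(C)C#N`: 30%

In an assay on isolated protein for binding affinity to leukotriene B4 receptor 1 (Homo sapiens), tested at 1 uM (on this read-out lower numbers stand for less inhibition and higher numbers for more inhibition at the one concentration tested (going by the name of the read-out)), compound 1 gives 35% and compound 2 gives 30%. These two values lie within the usual scatter of each other, so neither compound can be set apart from the other on this basis. Compound 3 `CCc1cc(C(C)=O)c(O)cc1OCCCC(C)(C)c1nnn[nH]1` has not yet been measured in this assay. It differs from compound 2 in one place: 1-(1H-tetrazol-5-yl)-1-methylethyl in place of 2-cyano-2-methylpropyl on a saturated chain carbon, three bonds along the chain from an oxygen on an aromatic ring. Going by the values given here, no measured pair shows a step of this kind. The expected step in this assay is a number 22 percentage points higher from compound 2 to compound 3 (beyond the scatter), a rise that would exceed the scatter. Compound 3 is estimated at 52%, with a range from 25% to 80%.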

Compound 3, a percentage reported as inhibition, at one concentration (the size of the read-out at that concentration, not a potency): 76%
The estimate for compound 3 lay 24 percentage points below the measured number; low and high end bracket the measured number.
By their numbers in this assay, from the lowest: compounds 2 and 1 (each within the scatter of the next); then compound 3.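

Putting 1-(1H-tetrazol-5-yl)-1-methylethyl in place of 2-cyano-2-methylpropyl gives, in this assay, a number 46 percentage points higher from compound 2 to compound 3 (beyond the scatter), so the group on this saturated chain carbon, three bonds along the chain from an oxygen on an aromatic ring, strongly shapes the read-out. No earlier pair had shown a step at this place. Nothing available explains the size of this step. Going by these compounds, whether a carboxylic acid in place of the tetrazole would match compound 3 remains open, as does whether a longer chain carrying the tetrazole would keep the gain.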